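A few compounds are considered here, and "the series" means these few. Any claim that something is new, unique, unknown or untested is made for them only; others in the source may bear on it.

Series notes. In a functional assay on A549 cells (Homo sapiens) for antiproliferative activity, read by MTT assay, with a stated time of 48 h (a lower number here means a stronger inhibitor of growth, a higher number a weaker inhibitor of growth), compound 1 `Cc1ccc(OCCCCN(Cc2ccc(C(=O)NO)cc2)c2ncc(-c3ccc(C)cc3)s2)cc1` gives 8630 nM, compound 2 `CCCCN(Cc1ccc(C(=O)NO)cc1)c1ncc(-c2ccc(C)cc2)s1` gives 4780 nM and compound 3 `CCCN(Cc1ccc(C(=O)NO)cc1)c1ncc(-c2ccc(C)cc2)s1` gives 3310 nM. Compound 3 holds the lowest of the three numbers; compound 2 sits within the scatter of it, compound 1 beyond it. Compound 4 `CCN(Cc1ccc(C(=O)NO)cc1)c1ncc(-c2ccc(C)cc2)s1` differs from compound 3 by hydrogen in place of methyl on a saturated chain carbon, two bonds along the chain from a nitrogen on an aromatic ring. The chain-trimming steps already measured bear on this: a 1.4-fold lower number from compound 2 to compound 3 (0.16 log units; within the scatter) and a 1.8-fold lower number from compound 1 to compound 2 (0.26 log units; within the scatter), with only the combined a 2.6-fold lower number from compound 1 to compound 3 (0.42 log units; beyond the scatter) reaching beyond the scatter. A step in this assay no larger than the scatter is therefore expected, if anything toward a lower number. Compound 4 is estimated at 2800 nM, between 1400 nM and 5600 nM, which means an expected step of a 1.2-fold lower number from compound 3 to compound 4 (0.07 log units; within the scatter).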

Compound 4, concentration for 50% growth inhibition: 2700 nM
For compound 4 the middle estimate is 1.0-fold (0.02 log units) above the measured one; measured number inside the range.
By their numbers in this assay, from the lowest: compounds 4, 3, 2 and 1 (each within the scatter of the next, the first and the last beyond it).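

Across the short chains in this assay, the numbers stay within the scatter when propyl gives way to ethyl (a 1.2-fold lower number from compound 3 to compound 4 (0.09 log units; within the scatter)) and when the butyl of compound 2 is cut to the ethyl of compound 4 (a 1.8-fold lower number from compound 2 to compound 4 (0.25 log units; within the scatter)). Against the 4-methylphenoxy chain end, the ethyl compound extends the modest step beyond the scatter (a 3.2-fold lower number from compound 1 to compound 4 (0.50 log units; beyond the scatter)). No measurement available explains these steps. Still open, from the compounds shown here alone, is whether methyl in place of ethyl keeps this flat range, and whether an amine or a carboxylic acid in place of 4-methylphenoxy departs from it.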